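Carbamate Aryl Swaps on a Shared Core in PANC-1 Cells

A few compounds are considered here, and "the series" means these few. Any claim that something is new, unique, unknown or untested is made for them only; others in the source may bear on it.

Measured compounds:
compound 1, `COc1ccc(NC(=O)Oc2cc(=O)n(CCCO)c3c2CC(CC=C(C)C)C(C)(C)C3)cc1`, 3.7%
compound 2, `CC(C)=CCC1Cc2c(OC(=O)Nc3ccccc3F)cc(=O)n(CCCO)c2CC1(C)C`, 52.3%
compound 3, `CC(C)=CCC1Cc2c(OC(=O)Nc3ccc(F)cc3F)cc(=O)n(CCCO)c2CC1(C)C`, 69.7%

In a functional assay on PANC-1 cells (Homo sapiens) for inhibition, read by MTT assay, with a stated time of 24 h, tested at 10 uM (a lower number here means less inhibition, a higher number more inhibition at the concentration tested (going by the name of the read-out)), compound 3 stands highest of the three, with compound 2 nearest and compound 1 furthest. The two steps from compound 1 are large: a number 48.6 percentage points higher from compound 1 to compound 2 (beyond the scatter) and a number 66 percentage points higher from compound 1 to compound 3 (beyond the scatter). Between the two fluorinated compounds the step is smaller: a number 17.4 percentage points higher from compound 2 to compound 3 (beyond the scatter).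

Compound 4, `CC(C)=CCC1Cc2c(OC(=O)Nc3ccc(Cl)cc3)cc(=O)n(CCCO)c2CC1(C)C`, has not been measured. It differs from compound 3 in one place: 4-chlorophenyl in place of 2,4-difluorophenyl on an amide-type nitrogen. For the measured compounds named here, no measured step pairs a chlorine-bearing aryl group with a fluorine-bearing one, so the bearing steps are indirect. The step from compound 1 to compound 3 shows that a 4-methoxyphenyl group is far weaker than 2,4-difluorophenyl, and the step from compound 2 to compound 3 shows that the fluoro on the aromatic carbon adds a modest amount. Compound 4 keeps neither fluoro and carries a different single substituent, so a step downward is expected, estimated at a number 24.7 percentage points lower from compound 3 to compound 4 (beyond the scatter). Compound 4 is therefore expected to give 45%, within a range from 15% to 72%.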

Compound 4, a percentage reported as inhibition, at one concentration (the size of the read-out at that concentration, not a potency): 49.8%
The estimate for compound 4 lay 4.8 percentage points below the measured number; measured number inside the range.
By their numbers in this assay, from the lowest: compound 1; then compounds 4 and 2 (each within the scatter of the next); then compound 3.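

In this assay, the aryl group on the amide-type nitrogen does not need fluorine to give a clear gain over 4-methoxyphenyl: with chloro in place of methoxy on an aromatic carbon, the reading shows a number 46.1 percentage points higher from compound 1 to compound 4 (beyond the scatter). The 4-chlorophenyl and 2-fluorophenyl groups cannot be told apart here, with a number 2.5 percentage points lower from compound 2 to compound 4 (within the scatter), whereas 2,4-difluorophenyl remains separated from 4-chlorophenyl, with a number 19.9 percentage points lower from compound 3 to compound 4 (beyond the scatter). The data offer no evidence on what underlies these differences.

The compounds shown leave open whether 2,4-dichlorophenyl would match 2,4-difluorophenyl, and how an aryl group carrying an amine or a carboxylic acid would read at this nitrogen. On these data alone, because each compound has a reading at a single concentration, their potencies also remain open.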